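A fluorine step repeated on a weaker benzylic analogue

A few compounds are considered here, and "the series" means these few. Any claim that something is new, unique, unknown or untested is made for them only; others in the source may bear on it.

Measured compounds:
compound 1, `O/N=C(/Nc1cccc(Cl)c1)c1ccc2occc2c1`, 690 nM
compound 2, `O/N=C(/Nc1ccc(F)c(Cl)c1)c1ccc2occc2c1`, 5200 nM
compound 3, `O/N=C(/NCc1cccc(Cl)c1)c1ccc2occc2c1`, a limit, > 30000 nM

The study concerns three measured compounds and one that is not yet measured, all read in an assay on isolated protein for inhibition of Indoleamine 2,3-dioxygenase 1 (Homo sapiens), read by spectrophotometry; a higher number here means a weaker inhibitor, a lower number a stronger inhibitor. Compound 1 `O/N=C(/Nc1cccc(Cl)c1)c1ccc2occc2c1` gives 690 nM in this assay. Compound 2 `O/N=C(/Nc1ccc(F)c(Cl)c1)c1ccc2occc2c1` differs from it by fluoro in place of hydrogen on an aromatic carbon and gives 5200 nM; the step is a 7.5-fold higher number from compound 1 to compound 2 (0.88 log units; beyond the scatter).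

Compound 3 `O/N=C(/NCc1cccc(Cl)c1)c1ccc2occc2c1` reaches only a limit of the assay, > 30000 nM, so the number itself is not known; this is the case described by the limit of > 30000 nM in this assay, at which 1 of the 3 values shown sits. How the core of compound 3 differs from the core of compound 1 is not broken down here.

Compound 4 `O/N=C(/NCc1ccc(F)c(Cl)c1)c1ccc2occc2c1` has not been measured. Going by the values given here, it differs from compound 3 by fluoro in place of hydrogen on an aromatic carbon, the same change as the one from compound 1 to compound 2. Since that earlier step was a 7.5-fold higher number from compound 1 to compound 2 (0.88 log units; beyond the scatter), and since compound 3 already sits at a limit with > 30000 nM, compound 4 is expected to be weaker still, and the expected step is a step that the limit leaves unreadable from compound 3 to compound 4. The value expected for compound 4 in this assay is 80000 nM, in a range of 30000 nM to 300000 nM, and most likely the assay will again report only a limit.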

Compound 4, half-maximal inhibitory concentration: 22000 nM
Beside the measured number, compound 4's estimate is 3.6-fold (0.56 log units) above it, and the stated range ends above it.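

In this assay, fluoro in place of hydrogen on an aromatic carbon of the core of compound 3 gives an at least 1.3-fold lower number from compound 3 to compound 4 (0.13 log units; that floor lies within the scatter); that floor alone does not establish a real gain in potency. Even so, the change did not carry over from the core of compound 1 to the core of compound 3 as a step of the same size and direction, and the earlier loss cannot be taken as a guide to this second core: the same change on two cores in this assay, a 7.5-fold higher number (0.88 log units; beyond the scatter) from compound 1 to compound 2 and an at least 1.3-fold lower number (0.13 log units; that floor lies within the scatter) from compound 3 to compound 4, at least 10-fold (1.01 log units) apart, beyond the scatter of two such steps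

Compound 3 is reported only as a limit, so the true size of the new step stays unknown, and the comparison shows that the two cores differ without showing why: the limit of > 30000 nM in this assay, at which 1 of the 4 values shown sits.

Going by these compounds alone, with only two pairs, this is a contrast between two cores and not a rule for the series, and whether either result is the more typical remains unsettled. Going by these compounds, it also remains open how a methoxy group or a second chloro group would behave in place of the fluoro group on each core, and whether a longer chain in place of the benzylic link would follow compound 1 and compound 2 or compound 3 and compound 4.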